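Swapping isopropyl for methoxycarbonyl in compound 1

The source may hold more compounds than are shown below. What is called first, only, known or untested is meant among the compounds shown, and "the series" means these compounds.

In an ADME assay on L6 cells (Rattus norvegicus) for cytotoxicity, read by resazurin assay, with a stated time of 72 h (on this read-out lower numbers stand for stronger inhibition and higher numbers for weaker inhibition), compound 1 `CC(C)c1ccc(C(=O)NC(=O)c2ccccc2O)cc1` gives 19 ug/mL. Compound 3 `O=C(NC(=O)c1ccccc1O)c1ccc(F)cc1`, with fluoro in place of isopropyl, gives 38 ug/mL. For the measured compounds named here, these two values stand together at the low end of the numbers available so far. Compound 2 `O=C(NC(=O)c1ccccc1O)c1ccc(-c2ccccc2)cc1`, with phenyl at the same place, reports only a limit of > 100 ug/mL.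

Compound 4 `COC(=O)c1ccc(C(=O)NC(=O)c2ccccc2O)cc1` has not yet been measured. Its change from compound 1 is methoxycarbonyl in place of isopropyl on an aromatic carbon.

Two measured replacements of isopropyl bear on this change. Fluoro in compound 3 gives a 2.0-fold higher number from compound 1 to compound 3 (0.30 log units; within the scatter), while phenyl in compound 2 gives an at least 5.2-fold higher number from compound 1 to compound 2 (0.72 log units; beyond the scatter). Neither moves towards a lower number beyond the scatter, so a modest rise seems more likely than a fall, although two examples are a thin basis.

The expected step is a 1.8-fold higher number from compound 1 to compound 4 (0.27 log units; within the scatter), a small one towards a higher number. For compound 4, the estimated value is 35 ug/mL, with an expected range of 14 ug/mL to 90 ug/mL.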

Compound 4, half-maximal inhibitory concentration: 42 ug/mL
The estimate for compound 4 lay 1.2-fold (0.08 log units) below the measured number; measured number inside the range.
By their numbers in this assay, from the lowest: compounds 1, 3 and 4 (each within the scatter of the next, the first and the last beyond it). At a limit, above all of these: compound 2.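

In this assay, methoxycarbonyl brings two hydrogen-bond acceptors where isopropyl has none, and this replacement gives a 2.2-fold higher number from compound 1 to compound 4 (0.34 log units; beyond the scatter), a modest rise that lies beyond the scatter, unlike the step to the fluoro compound. Exchanging fluoro for methoxycarbonyl gives a 1.1-fold higher number from compound 3 to compound 4 (0.04 log units; within the scatter), so these two groups cannot be told apart at this position in this assay. Exchanging phenyl for methoxycarbonyl gives an at least 2.3-fold lower number from compound 2 to compound 4 (0.37 log units; beyond the scatter), a step that starts from a limit and not from a true number: the limit of > 100 ug/mL in this assay, at which 1 of the 4 values shown sits.

From the compounds shown here alone, whether an amine, a carboxylic acid or a longer chain at this position would give a lower number than compound 1 stays open. Equally open, going by these compounds, is where the true number of compound 2 lies beyond its limit.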